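Pyridinyl dithiocarbamate benzamides: shifting the ring nitrogen

A few compounds are considered here, and "the series" means these few. Any claim that something is new, unique, unknown or untested is made for them only; others in the source may bear on it.

Two compounds of the series have numbers in a functional assay on A-375 cells (Homo sapiens) for antiproliferative activity, read by CCK-8 assay, with a stated time of 72 h, tested at 8 uM; on this read-out lower numbers stand for a weaker effect and higher numbers for a stronger effect at the one concentration tested. Compound 1 `Nc1ccccc1NC(=O)c1ccc(CSC(=S)N2CCc3ccccc32)cc1` is one of them; in this assay compound 1 gives 85.4%. Compound 2 `Nc1ccccc1NC(=O)c1ccc(CSC(=S)N2CCN(c3cccnc3)CC2)cc1` is the other, carrying pyridin-3-yl on an amine nitrogen in a ring; in this assay compound 2 gives 88.8%. Compound 2 therefore stands alongside compound 1 at the upper end of the read-out, and the gap between the two numbers lies within the scatter, so the two cannot be set apart. For the measured compounds named here, no pair of measured compounds differing in a single place is available, so no computed step size exists for the series.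

Compound 3 `Nc1ccccc1NC(=O)c1ccc(CSC(=S)N2CCN(c3ccncc3)CC2)cc1` has the same atoms as compound 2, joined differently: pyridin-4-yl in place of pyridin-3-yl on an amine nitrogen in a ring. Nothing else in the structure is altered. With compound 1 and compound 2 both sitting high in this assay, a shift beyond the scatter in either direction is not expected, and the expected step is a number 1.8 percentage points lower from compound 2 to compound 3 (within the scatter), with limited room upward. Compound 3 is expected to give 87% in this assay, within a range from 75% to 95%.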

Compound 3, a percentage reported as inhibition, at one concentration (the size of the read-out at that concentration, not a potency): 90.7%
Beside the measured number, compound 3's estimate is 3.7 percentage points below it; the range from low to high includes it.
By their numbers in this assay, from the lowest: compounds 1, 2 and 3 (each within the scatter of the next).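

Replacing pyridin-3-yl with pyridin-4-yl on the amine nitrogen in a ring gives the series its first comparison that differs in one place, and in this assay this change reads as a number 1.9 percentage points higher from compound 2 to compound 3 (within the scatter). At this position, the two pyridine attachments therefore cannot be set apart at the one concentration tested, and this single read-out gives no measure of potency for either compound. Nothing available bears on the reason for this outcome.

Open, on these data alone, is whether pyridin-2-yl, or a plain phenyl ring with no ring nitrogen, on the same amine nitrogen would stay within the scatter of compound 2 in this assay. Also open, as far as these compounds go, is whether a full concentration series could separate compound 2 and compound 3, since a single concentration at this height of the read-out leaves any such difference unresolved.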